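The source may report more compounds than this note shows. Statements on the series, on what has been measured and on what is new or still open speak of the compounds shown alone.

Measured so far in an ADME assay for permeability, using PAMPA, with a stated time of 6 h, at pH 7.4; a higher number here means that the compound crosses the layer faster, a lower number that the compound crosses the layer more slowly:
- compound 1 `C#CCNC1=CC(=O)c2cccc(OC)c2C1=O` gives 18.8 10^-6 cm/s
- compound 2 `C#CCNC1=CC(=O)c2c(O)ccc(O)c2C1=O` gives 43.3 10^-6 cm/s
- compound 3 `C#CCNC1=CC(=O)c2cccc(OCc3ccccc3)c2C1=O` gives 25.5 10^-6 cm/s

Compound 3 lies within the scatter of both other compounds, so the three-compound set gives it no clear rank. The next compound to consider is compound 4 `C#CCNC1=CC(=O)c2ccccc2C1=O`, which has hydrogen in place of benzyloxy on an aromatic carbon. This removes the whole group and leaves the shared core otherwise unchanged.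

Within the data shown here, one measured step bears on this change. It is a 1.4-fold higher number from compound 1 to compound 3 (0.13 log units; within the scatter), and it concerns the same oxygen-bound group on the aromatic ring. Among the measured compounds shown here, no measured step removes that group entirely, so the expectation rests on an extrapolation. Compound 2 differs from compound 3 in more than one place and offers only its value as a guide to the upper part of the range.

With so little evidence, no step beyond the scatter is expected in this assay, and no direction is favoured. The estimated step is a 1.0-fold lower number from compound 3 to compound 4 (0.01 log units; within the scatter). The expected value for compound 4 is 25 10^-6 cm/s, with an estimated range from 12 10^-6 cm/s to 48 10^-6 cm/s.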

Compound 4, apparent permeability: 20.8 10^-6 cm/s
Compound 4: middle estimate off by 1.2-fold (0.08 log units), on the high side; low and high end bracket the measured number.
By their numbers in this assay, from the lowest: compounds 1, 4, 3 and 2 (each within the scatter of the next, the first and the last beyond it).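

In this assay, taking the benzyloxy group off the aromatic carbon, a loss of 8 heavy atoms including one six-membered aromatic ring, gives a 1.2-fold lower number from compound 3 to compound 4 (0.09 log units; within the scatter) and hydrogen in place of methoxy gives a 1.1-fold higher number from compound 1 to compound 4 (0.04 log units; within the scatter) as the second reading of the same place. Among these compounds, compound 4 adds the case with no group at this carbon, which the earlier compounds lacked, and the steps among hydrogen, methoxy and benzyloxy now all lie within the scatter, so for compound 1, compound 3 and compound 4 the read-out shows no clear dependence on which of these three groups sits here. No measurement on hand offers an explanation for these small steps.

As far as these compounds go, all three groups at this carbon are either hydrogen or an ether oxygen carrying carbon, so it remains open whether the same reading would hold for an amine or a carboxylic acid at this place. From the compounds shown here alone, what a single hydroxy group at this carbon would give also remains open, and compound 2, which differs from the other three compounds in more than one place, does not settle it.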